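The source may report more compounds than this note shows. Statements on the series, on what has been measured and on what is new or still open speak of the compounds shown alone.

Measured in a functional assay on SKHep cells (Homo sapiens) for antiproliferative activity, read by MTT assay, with a stated time of 12 h; on this read-out higher numbers stand for weaker inhibition and lower numbers for stronger inhibition:

Compound 1 `COc1cc(OC)c2c(=O)cc(/C=C/c3ccc(OCC4CC4)cc3)oc2c1` gives 22100 nM.
Compound 2 `COc1cccc2oc(/C=C/c3ccc(OC(F)(F)F)cc3)cc(=O)c12` gives 21000 nM.
Compound 3 `COc1cc(OC)c2c(=O)cc(/C=C/c3ccc(C(F)(F)F)cc3)oc2c1` gives 20600 nM.

Compound 3 holds the lowest of the three numbers in this assay, yet its two neighbours stand within the scatter of it, so no order among the three can be read. Compound 4 `COc1cc(OC)c2c(=O)cc(/C=C/c3ccc(OC(F)(F)F)cc3)oc2c1` differs from compound 3 by one change: trifluoromethoxy in place of trifluoromethyl on an aromatic carbon. Among the compounds with values here, only one measured step touches this position, a 1.1-fold lower number from compound 1 to compound 3 (0.03 log units; within the scatter), and it lies within the scatter. Compound 2 also carries trifluoromethoxy on a different core and its value sits close to that of compound 3. On that basis no step beyond the scatter is expected, so compound 4 is estimated at 21000 nM, between 10500 nM and 42000 nM, an expected step of a 1.0-fold higher number from compound 3 to compound 4 (0.01 log units; within the scatter).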

Compound 4, half-maximal inhibitory concentration: 12500 nM
Estimate against measurement, compound 4: 1.7-fold (0.23 log units) above, within the range that was stated.
By their numbers in this assay, from the lowest: compounds 4, 3, 2 and 1 (each within the scatter of the next).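

In this assay, trifluoromethoxy in place of trifluoromethyl on this aromatic carbon gives a 1.6-fold lower number from compound 3 to compound 4 (0.22 log units; within the scatter) and so stays inside the scatter, as the earlier change here did. Methoxy in place of hydrogen on the core gives a 1.7-fold lower number from compound 2 to compound 4 (0.23 log units; within the scatter) and adds a first reading away from this position, while trifluoromethyl in place of cyclopropylmethyl on the oxygen gives a 1.8-fold lower number from compound 1 to compound 4 (0.25 log units; within the scatter) and likewise moves nothing beyond the scatter. No measurement offers an explanation for these numbers. The compounds shown leave open whether an amine or a carboxylic acid on this aromatic carbon would give a step beyond the scatter.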